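This account rests on a few compounds, and the source may have more. Where it says the series, first, only, none or still open, it means among the compounds named here.

Of the compounds shown here, three built on one shared core have been measured in a functional assay on A549 cells (Homo sapiens) for inhibition, read by CCK-8 assay, with a stated time of 48 h; on this read-out lower numbers stand for stronger inhibition and higher numbers for weaker inhibition. Compound 1 `COc1ccc(-c2cc3nccc(-c4cc(OC)c(OC)c(OC)c4)n3n2)cc1N` gives 138 nM. Compound 2 `COc1cc(-c2ccnc3cc(-c4ccc(C(C)=O)cc4)nn23)cc(OC)c1OC` gives 4100 nM. Compound 3 `COc1ccc(-c2cc3nccc(-c4cc(OC)c(OC)c(OC)c4)n3n2)cc1F` gives 545 nM, the second highest of the three numbers. The nearest of the other numbers is reached by a 3.9-fold higher number from compound 1 to compound 3 (0.60 log units; beyond the scatter), the furthest by a 7.5-fold lower number from compound 2 to compound 3 (0.88 log units; beyond the scatter).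

Compound 4 `COc1cc(-c2ccnc3cc(-c4ccccc4)nn23)cc(OC)c1OC` differs from compound 3 in one place: phenyl in place of 3-fluoro-4-methoxyphenyl on an aromatic carbon. For the measured compounds named here, two measured steps bear on this change. The step of a 7.5-fold lower number from compound 2 to compound 3 (0.88 log units; beyond the scatter) shows that the 3-fluoro-4-methoxyphenyl group gives a markedly lower number in this assay than a 4-acetylphenyl group, while the step of a 3.9-fold higher number from compound 1 to compound 3 (0.60 log units; beyond the scatter) shows a modest cost when fluoro replaces amino. Compound 4 carries neither the fluoro nor the methoxy group, so a modest rise in the number, beyond the scatter but well short of the large gap seen with compound 2, is expected. The expected step is a 2.8-fold higher number from compound 3 to compound 4 (0.44 log units; beyond the scatter). For compound 4 a value of 1500 nM is estimated, within a range from 500 nM to 5000 nM.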

Compound 4, half-maximal inhibitory concentration: 208 nM
Compound 4: the middle estimate sits 7.2-fold (0.86 log units) above what was measured; measured number outside the range, below it.
By their numbers in this assay, from the lowest: compounds 1 and 4 (each within the scatter of the next); then compound 3; then compound 2.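

In this assay, a plain phenyl on this aromatic carbon of the five-membered ring gives a lower number than the 3-fluoro-4-methoxyphenyl group (a 2.6-fold lower number from compound 3 to compound 4 (0.42 log units; beyond the scatter)), so among these compounds a low number here does not depend on substituents on the phenyl. The high number of compound 2 goes with its acetyl rather than with the phenyl ring itself, as hydrogen in place of acetyl shows (a 20-fold lower number from compound 2 to compound 4 (1.29 log units; beyond the scatter)). The amino-bearing group of compound 1 cannot be told apart from plain phenyl (a 1.5-fold higher number from compound 1 to compound 4 (0.18 log units; within the scatter)), so the amino and methoxy pair shows no measurable gain over phenyl here.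

No measurement given here explains these differences. On these data alone, whether a lone amino or lone methoxy group on the phenyl, or a carboxylic acid in place of the acetyl, would move the number remains open.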